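A few compounds are considered here, and "the series" means these few. Any claim that something is new, unique, unknown or untested is made for them only; others in the source may bear on it.

Measured so far:
Compound 1 `COc1ccc(-c2cc3ccccc3nc2C=O)cc1`: in a functional assay on MCF7 cells (Homo sapiens) for antiproliferative activity, read by XTT assay, with a stated time of 72 h (on this read-out higher numbers stand for weaker inhibition and lower numbers for stronger inhibition), compound 1 gives > 10000 nM, which is a limit of the assay rather than a number.
Compound 2 `COc1ccc(-c2cc3ccccc3nc2/C=C/C(=O)c2ccc(F)cc2)cc1`: in this assay compound 2 gives 5450 nM.
Compound 3 `COc1ccc(-c2cc3ccccc3nc2/C=C/C(=O)c2ccc(O)cc2)cc1`: in this assay compound 3 gives 6710 nM.

Compound 3 and compound 2 lie within the usual scatter of each other, so neither can be called the more potent. Compound 1 sits at the limit of > 10000 nM in this assay, at which 1 of the 3 values shown sits, and gives no number to compare.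

Compound 4 `COc1ccc(-c2cc3ccccc3nc2/C=C/C(=O)c2ccc(OC)c(OC)c2)cc1` differs from compound 3 by 3,4-dimethoxyphenyl in place of 4-hydroxyphenyl on a carbonyl carbon. Among the measured compounds shown here, only one measured step touches the same ring: a 1.2-fold higher number from compound 2 to compound 3 (0.09 log units; within the scatter), a change of one small group for another that stayed within the scatter. On that basis compound 4 is expected to show no step beyond the scatter in this assay, namely a 1.1-fold lower number from compound 3 to compound 4 (0.05 log units; within the scatter). Compound 4 is therefore estimated at 6000 nM, with a likely range from 2500 nM to 15000 nM.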

Compound 4, half-maximal inhibitory concentration: 6030 nM
Compound 4: the middle estimate sits 1.0-fold (0.00 log units) below what was measured; the range from low to high includes it.
By their numbers in this assay, from the lowest: compounds 2, 4 and 3 (each within the scatter of the next). At a limit, above all of these: compound 1.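

Replacing 4-hydroxyphenyl on the carbonyl carbon with 3,4-dimethoxyphenyl, a larger change than swapping one small group, gives a 1.1-fold lower number from compound 3 to compound 4 (0.05 log units; within the scatter) in this assay. Set against 4-fluorophenyl, the same group gives a 1.1-fold higher number from compound 2 to compound 4 (0.04 log units; within the scatter), so at this position all three rings read alike within the scatter. Nothing measured here accounts for this flat result.

Still open, on these data alone, is whether an amine or a carboxylic acid on this ring would move the number beyond the scatter. The same holds for a longer chain in place of the ring.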